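Adding a methoxy group: cytotoxicity on macrophage cells

This account rests on a few compounds, and the source may have more. Where it says the series, first, only, none or still open, it means among the compounds named here.

Measured so far:
compound 1 `COc1ccc(C(=O)CCc2ccc(OC)cc2OC)c(O)c1` gives 97.8%
compound 2 `COc1ccc(C(=O)CCc2ccc(OC)c(OC)c2)c(O)c1` gives 91.8%

Both compounds were tested in an ADME assay on RAW264.7 cells (Mus musculus) for cytotoxicity, read by MTT assay, with a stated time of 24 h, tested at 1.25 ug/mL; on this read-out higher numbers stand for a weaker effect at the one concentration tested and lower numbers for a stronger effect. In this assay compound 1 gives 97.8% and compound 2 gives 91.8%; the two figures sit within the usual scatter of one another, so compound 2 stands alongside compound 1 rather than apart from it, and both read as nearly untouched cells.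

Compound 3 `COc1ccc(C(=O)CCc2ccc(OC)c(OC)c2OC)c(O)c1` has not yet been measured. It differs from compound 2 by methoxy in place of hydrogen on an aromatic carbon, a methoxy in place of hydrogen on an aromatic carbon. Going by the values given here, no step between measured compounds is known here, and both measured values lie close to full activity, so the expected step of a number 1.2 percentage points higher from compound 2 to compound 3 (within the scatter) is none beyond the scatter, in either direction. Compound 3 is therefore expected to give about 93%, estimated between 82% and 100%, in this assay.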

Compound 3, a percentage reported as activity, at one concentration (the size of the read-out at that concentration, not a potency): 101%
Compound 3: middle estimate off by 8 percentage points, on the low side, and the stated range ends below it.
By their numbers in this assay, from the lowest: compounds 2, 1 and 3 (each within the scatter of the next).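

In this assay methoxy in place of hydrogen on the aromatic carbon that sits ortho to a large group and ortho to a methoxy group gives a number 9.2 percentage points higher from compound 2 to compound 3 (within the scatter) and, counted from the other starting compound, a number 3.2 percentage points higher from compound 1 to compound 3 (within the scatter). Neither step leaves the usual scatter, so at the one concentration tested this position takes a methoxy group with no detectable change in the read-out. Nothing given here offers a reason for this result.

On these data alone, whether a different group at this position, such as an amine or a carboxylic acid, would also leave the read-out unchanged remains open. Also open, as far as these compounds go, is how these compounds behave at higher concentrations, as a single concentration gives no measure of potency.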